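From 1H-imidazol-2-yl to 4-fluorophenyl on the carbonyl carbon

This account rests on a few compounds, and the source may have more. Where it says the series, first, only, none or still open, it means among the compounds named here.

In an ADME assay on microsomes from liver (Homo sapiens) for metabolic stability (a higher number here means that the compound lasts longer, a lower number that the compound disappears faster), compound 1 `COc1ccc(-c2cnc(NC(=O)c3ncc[nH]3)n2C)cc1` gives > 4.25 h, which is a limit of the assay and not a number. Compound 1 therefore stands at the limit of > 4.25 h in this assay, at which 1 of the 2 values shown sits.

The next compound, compound 3 `COc1ccc(-c2cnc(NC(=O)c3ccc(F)cc3)n2C)cc1`, keeps the core of compound 1 and places 4-fluorophenyl in place of 1H-imidazol-2-yl on a carbonyl carbon.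

For the measured compounds named here, no measured step isolates this change. The nearest evidence is compound 2 `O=C(Nc1ncc(-c2ccccc2)o1)c1ccc(F)cc1`, which has a different core but also carries 4-fluorophenyl on a carbonyl carbon and gives 0.317 h. On that value, a shorter half-life beyond the scatter is expected in this assay, and the expected step is an at least 4.2-fold lower number from compound 1 to compound 3 (0.62 log units; beyond the scatter). Compound 3 is estimated at 1 h, with an expected range of 0.3 h to 3.5 h.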

Compound 3, half-life: 0.983 h
Estimate against measurement, compound 3: 1.0-fold (0.01 log units) above; the range from low to high includes it.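

In this assay, 4-fluorophenyl in place of 1H-imidazol-2-yl on a carbonyl carbon comes with an at least 4.3-fold lower number from compound 1 to compound 3 (0.63 log units; beyond the scatter) and so now has a direct reading within one core. For the compounds shown here, until now, the only compound with 4-fluorophenyl at this place was compound 2, whose core differs, so it could not isolate the change. The step gives only a minimum size because compound 1 stands at a limit of the assay and not at a number: the limit of > 4.25 h in this assay, at which 1 of the 3 values shown sits.

The compounds shown leave open whether a plain phenyl, a pyridine ring or an aliphatic amine on the carbonyl carbon would stay with compound 1 or fall with compound 3. They also do not tell which part of the change, the loss of 1H-imidazol-2-yl or the entry of 4-fluorophenyl, carries the step.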